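Adding a Methoxy Group to an Amide

This account rests on a few compounds, and the source may have more. Where it says the series, first, only, none or still open, it means among the compounds named here.

Compound 1 `Cc1cccc(C(=O)N2CCCC(C(=O)Nc3ccc(Cl)cc3)C2)c1` was tested in an ADME assay on PC-3 cells (Homo sapiens) for cytotoxicity, read by WST assay, tested at 100 uM (a lower number here means less inhibition, a higher number more inhibition at the concentration tested (going by the name of the read-out)), where compound 1 gives 0%. Two related compounds share its core. Within the data shown here, compound 2 `O=C(Nc1cccc(Oc2ccccc2)c1)C1CCCN(C(=O)c2cc(C(F)(F)F)cc(C(F)(F)F)c2)C1` gives 1%, and compound 3 `O=C(Nc1cccc(S(=O)(=O)N2CCCC2)c1)C1CCCN(C(=O)c2cc(C(F)(F)F)cc(C(F)(F)F)c2)C1` gives 0%; the single measured step between them, a number 1 percentage points lower from compound 2 to compound 3 (within the scatter), lies within the scatter. Compound 1 stands level with compound 3 at the digits shown, and its gap to compound 2 is also within the scatter, so all three numbers are indistinguishable here.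

Compound 4 `COCc1cccc(C(=O)N2CCCC(C(=O)Nc3ccc(Cl)cc3)C2)c1` differs from compound 1 by one change: methoxy in place of hydrogen on a saturated chain carbon bound to an aromatic carbon. Among the measured compounds shown here, no measured step touches this position; the only step available, a number 1 percentage points lower from compound 2 to compound 3 (within the scatter), concerns a different part of the molecule and did not move the read-out beyond the scatter. With every measured compound giving a number at the low end of the scale, no shift beyond the scatter is expected, and compound 4 is estimated at 1%, between 0% and 12%, which means an expected step of a number 1 percentage points higher from compound 1 to compound 4 (within the scatter).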

Compound 4, a percentage reported as inhibition, at one concentration (the size of the read-out at that concentration, not a potency): 0%
Beside the measured number, compound 4's estimate is 1 percentage points above it; measured number inside the range.
By their numbers in this assay, from the lowest: compounds 1, 3, 4 and 2 (each within the scatter of the next).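

Among these compounds, the only earlier step concerned a different part of the molecule, so this is the first reading at the saturated chain carbon bound to an aromatic carbon. In this assay, methoxy in place of hydrogen there, which turns 3-methylphenyl into 3-(methoxymethyl)phenyl, brings no change at the digits printed from compound 1 to compound 4 (within the scatter) at the one concentration tested. With compound 1 at 0% already, the change adds no inhibition that can be told from the scatter, and no other measurement offers an explanation for this result.

Going by these compounds, whether an amine or a carboxylic acid on this same carbon, or a longer chain ending in methoxy, would also leave the number flat stays open. The numbers shown also cannot tell how compound 4 would behave at any other concentration.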